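The source may report more compounds than this note shows. Statements on the series, on what has been measured and on what is new or still open speak of the compounds shown alone.

Measured: compound 1 `COc1cc(N2C(N)=C(C#N)C(c3c(OC)ccc4ccccc34)C3=C2CC(C)(C)CC3=O)cc(OC)c1OC`, 10%; compound 2 `COc1cc(N2C(N)=C(C#N)C(c3ccccc3O)C3=C2CC(C)(C)CC3=O)cc(OC)c1OC`, 2%.

Among the compounds with values here, in a functional assay on Ehrlich cells (Mus musculus) for cytotoxicity, tested at 50 ug/mL (a higher number here means a stronger effect of the compound at the concentration tested, a lower number a weaker effect), compound 2 gives 2%, with compound 1 at 10% close by; the single measured step, a number 8 percentage points lower from compound 1 to compound 2 (within the scatter), lies within the scatter. Compound 3 `COc1cc(N2C(N)=C(C#N)C(c3ccc(OC)c4ccccc34)C3=C2CC(C)(C)CC3=O)cc(OC)c1OC` carries 4-methoxynaphthalen-1-yl in place of 2-hydroxyphenyl on a saturated ring carbon. Within the data shown here, the one step that bears on this, 2-methoxynaphthalen-1-yl against 2-hydroxyphenyl in a number 8 percentage points lower from compound 1 to compound 2 (within the scatter), changed nothing beyond the scatter, so in this assay no step beyond the scatter is expected either, a number 6 percentage points higher from compound 2 to compound 3 (within the scatter). Compound 3 is estimated at 8%, between 0% and 22%.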

Compound 3, a percentage reported as activity, at one concentration (the size of the read-out at that concentration, not a potency): 40%
Compound 3: the middle estimate sits 32 percentage points below what was measured; measured number outside the range, above it.
By their numbers in this assay, from the lowest: compounds 2 and 1 (each within the scatter of the next); then compound 3.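

In this assay the substituent on the saturated ring carbon can matter, with a number 38 percentage points higher from compound 2 to compound 3 (beyond the scatter) when 4-methoxynaphthalen-1-yl replaces 2-hydroxyphenyl. A naphthalene as such is not sufficient: the placement of the methoxy also counts, giving a number 30 percentage points higher from compound 1 to compound 3 (beyond the scatter) when 4-methoxynaphthalen-1-yl replaces 2-methoxynaphthalen-1-yl. No available measurement accounts for this rise.

Open, as far as these compounds go, is whether the methoxy of the 4-methoxynaphthalen-1-yl group is needed, or whether a hydroxy, a dimethylamino group or a carboxylic acid in its stead would do the same. From the compounds shown here alone, with a single tested concentration, how the effect changes at other concentrations also remains open.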